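The compounds below may be only part of what the source reports. "The series", "measured", "known", "first", "only" and "open" are said of these compounds alone.

Compounds measured in a functional assay on CHO cells for agonist activity at Alpha-1D adrenergic receptor (Homo sapiens), read by FLIPR and calcium flux; a lower number here means that less compound is needed, a higher number that more compound is needed for the effect:

Compound 1, `Cc1n[nH]cc1-c1cccc2c1CCC2c1ncc[nH]1`: 634 nM
Compound 2, `c1ccc2c(c1)CCC2c1ncc[nH]1`: > 10000 nM
Compound 3, `Cn1cc(-c2cccc3c2CCC3c2ncc[nH]2)cn1`: > 10000 nM

For compound 3 the value reported is a limit of the assay, not a number. The same holds for compound 2. Compound 1 is the only one of the three with a measured number, and the change from compound 1 to compound 2 gave an at least 15-fold higher number from compound 1 to compound 2 (1.19 log units; beyond the scatter), while the change from compound 1 to compound 3 gave an at least 15-fold higher number from compound 1 to compound 3 (1.19 log units; beyond the scatter). The comparison between compound 2 and compound 3 is a step that the two limits leave unreadable from compound 2 to compound 3.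

Compound 4, `c1cc(-c2nccs2)c2c(c1)C(c1ncc[nH]1)CC2`, has not yet been measured. It differs from compound 3 by 1,3-thiazol-2-yl in place of 1-methyl-1H-pyrazol-4-yl on an aromatic carbon. The two readable steps both start from compound 1 and end at a limit, so they show only that removing or methylating the 3-methyl-1H-pyrazol-4-yl group costs a great deal. Compound 4 also lacks that group; therefore no step beyond the scatter is expected relative to compound 3, and the estimated change is an at least 1.2-fold lower number from compound 3 to compound 4 (0.09 log units; that floor lies within the scatter). Compound 4 is expected to give about 8000 nM, within a range from 1500 nM to 30000 nM, in this assay.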

Compound 4, half-maximal effective concentration: 3190 nM
Estimate against measurement, compound 4: 2.5-fold (0.40 log units) above, within the range that was stated.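

In this assay, for the compounds shown here, the result shows that the 3-methyl-1H-pyrazol-4-yl group is not the only group on this aromatic carbon that gives a readable response, with an at least 3.1-fold lower number from compound 3 to compound 4 (0.49 log units; beyond the scatter) and an at least 3.1-fold lower number from compound 2 to compound 4 (0.49 log units; beyond the scatter). Both sizes are only floors, because the values they start from are limits of the assay: the limit of > 10000 nM in this assay, at which 2 of the 4 values shown sit. The 1,3-thiazol-2-yl group does not match the 3-methyl-1H-pyrazol-4-yl group, with a 5.0-fold higher number from compound 1 to compound 4 (0.70 log units; beyond the scatter), and it separates from 1-methyl-1H-pyrazol-4-yl even though both are five-membered aromatic rings with the same counts of hetero atoms, donors and acceptors, so these counts alone do not set the outcome.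

These compounds cannot show whether the sulfur atom or some other difference between the two rings accounts for the change. Going by these compounds, how an amine, a carboxylic acid or a plain phenyl ring would behave on this carbon also remains open.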